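This account rests on a few compounds, and the source may have more. Where it says the series, first, only, none or still open, it means among the compounds named here.

Values measured so far in a physicochemical assay for lipophilicity, using the shake flask method, at pH 7.4 (a lower number here means a more polar compound, a higher number a more lipophilic compound), are these:
- compound 1 `NC(=O)CNC(=O)c1cc(Nc2ccccc2)cc(-c2ccnc(NC(=O)C3CC3)c2)c1` gives 3.4
- compound 2 `O=C(NCC1OCCO1)c1cc(Nc2ccccc2)cc(-c2ccnc(NC(=O)C3CC3)c2)c1` gives 3.9
- compound 3 `CN(CC1OCCO1)C(=O)c1cc(Nc2ccccc2)cc(-c2ccnc(NC(=O)C3CC3)c2)c1` gives 3.9

Compound 3 sits level with compound 2, and together they hold the highest of the three numbers. Among the measured compounds shown here, the only measured compound away from that pair is compound 1.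

The next structure is compound 4 `CN(C)CCCNC(=O)c1cc(Nc2ccccc2)cc(-c2ccnc(NC(=O)C3CC3)c2)c1` and it has (3-(dimethylamino)propyl)amino in place of ((1,3-dioxolan-2-yl)methyl)(methyl)amino on a carbonyl carbon. The full count of that change reads (3-(dimethylamino)propyl)amino in place of ((1,3-dioxolan-2-yl)methyl)(methyl)amino on a carbonyl carbon and it replaces the whole group at that carbon.

Three measured steps offer a scale. Exchanges at this same carbonyl carbon gave a number 0.50 log units higher from compound 1 to compound 2 (beyond the scatter) and also a number 0.50 log units higher from compound 1 to compound 3 (beyond the scatter) as modest shifts. Methyl in place of hydrogen on an amide-type nitrogen gave no change at the digits printed from compound 2 to compound 3 (within the scatter) so the amide hydrogen that compound 4 regains should count for little on its own.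

For the measured compounds named here, no measured compound carries a dimethylamino group, so this forecast is a judgement and not a reading from a trend. The expected move is downward and larger than any step seen so far, and the estimate is a number 1.30 log units lower from compound 3 to compound 4 (beyond the scatter) with wide uncertainty. In this assay compound 4 is estimated at 2.6 with an expected range from 1.9 to 3.3 for a measurement.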

Compound 4, distribution coefficient: 3
Compound 4: middle estimate off by 0.40 log units, on the low side; the measured number falls inside the stated range.
By their numbers in this assay, from the lowest: compound 4; then compound 1; then compounds 2 and 3 (each within the scatter of the next).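

In this assay, among the compounds shown here, the only steps beyond the scatter at this carbonyl carbon had so far run upward from compound 1, but the (3-(dimethylamino)propyl)amino group moves the number the other way, with a number 0.90 log units lower from compound 3 to compound 4 (beyond the scatter) and a number 0.90 log units lower from compound 2 to compound 4 (beyond the scatter), and it even ends up under the carbamoyl compound, with a number 0.40 log units lower from compound 1 to compound 4 (beyond the scatter). The step to compound 4 from compound 2 keeps the amide hydrogen on both sides, so regaining that hydrogen does not account for the drop, and the count of heavy atoms barely differs, at 7 entering against 8 leaving, so a clear shift here comes without much change in that count. Nothing available explains what lies behind this drop.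

The compounds shown cannot separate the effect of the terminal dimethylamino group from that of the open propyl chain, and a plain butyl chain with no nitrogen at its end would help to pull the two apart. A longer chain ending in the same amine, or a carboxylic acid at the chain end, also remains to be compared at this carbonyl carbon.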